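The compounds below may be only part of what the source reports. "The series", "measured", "known", "first", "only" and "open" are said of these compounds alone.

Measured in a functional assay on A549 cells (Homo sapiens) for antiproliferative activity, read by MTT assay, with a stated time of 72 h; a lower number here means a stronger inhibitor, a higher number a weaker inhibitor:
- compound 1 `COc1cc(-c2ncnn2-c2cccc(N)c2)cc(OC)c1OC`: > 10000 nM
- compound 2 `COc1ccc(-c2ncnn2-c2cc(OC)c(OC)c(OC)c2)cc1`: 520 nM
- compound 3 `CCOc1ccc(-c2ncnn2-c2cc(OC)c(OC)c(OC)c2)cc1Cl`: 10 nM

Compound 1 stands at the limit of > 10000 nM in this assay, at which 1 of the 3 values shown sits. This is a limit and not a number, so any step from compound 1 has no exact starting point.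

Compound 4 `COc1cc(-c2ncnn2-c2ccc(N)cc2)cc(OC)c1OC` has not yet been measured. It keeps the core of compound 1, with 4-aminophenyl in place of 3-aminophenyl on an aromatic nitrogen. Among the compounds with values here, no measured pair isolates this change, so the expectation rests on thin ground. In this assay compound 2 gives 520 nM and compound 3 gives 10 nM, so clear activity does occur among these close relatives, although both differ from compound 1 in more than one place. The expected step of an at least 6.6-fold lower number from compound 1 to compound 4 (0.82 log units; beyond the scatter) is therefore towards a stronger inhibitor, possibly a large one, though a second result at the limit remains a real possibility. For compound 4 the estimated value is 1500 nM, with an expected range of 150 nM to 10000 nM.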

Compound 4, half-maximal inhibitory concentration: > 10000 nM
Compound 4 ended at the assay's limit (the forecaster's own chance of this, stated with the estimate: 35%); middle value at least 6.6-fold (0.82 log units) from the limit.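

In this assay compound 4 gives > 10000 nM, which is a limit. Within the data shown here, compound 1 also stands at a limit, so no step between compound 1 and compound 4 can be read. The compounds shown leave open how 3-aminophenyl and 4-aminophenyl truly compare on the shared core.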